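The source may report more compounds than this note shows. Statements on the series, on what has been measured and on what is new or still open speak of the compounds shown alone.

Compound 1 `O=c1ccc(CCCO)nn1Cc1ccccc1` was examined in a functional assay on aorta (Rattus norvegicus); a lower number here means a stronger inhibitor, a higher number a weaker inhibitor. In this assay compound 1 gives > 100000 nM, which is a limit of the assay rather than a measured number. Two further compounds share the core. Within the data shown here, compound 2 `Cn1nc(CO[Si](c2ccccc2)(c2ccccc2)C(C)(C)C)ccc1=O` gives 58400 nM in this assay, the only one of the three values that is a number. Compound 3 `Cn1nc(COCc2ccccc2)ccc1=O` gives > 100000 nM in this assay, again a limit rather than a number. Compound 1 thus stands at the limit of > 100000 nM in this assay, at which 2 of the 3 values shown sit, together with compound 3, while compound 2 sits only just inside the measurable range.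

The change from compound 1 to compound 4 `Cn1nc(CCCO)ccc1=O` is a single replacement: hydrogen in place of phenyl on a saturated chain carbon bound to an aromatic nitrogen. Among the measured compounds shown here, no step between two measured compounds describes this change, so there is no measured precedent for it here. Since compound 1 and compound 3 both sit at the limit of > 100000 nM in this assay, at which 2 of the 3 values shown sit, and compound 2 barely clears it, nothing in these numbers suggests that removing the phenyl would bring compound 4 into a clearly measurable range. The step from compound 1 to compound 4 is expected to be a step that the limit leaves unreadable from compound 1 to compound 4, no more than the usual scatter. Compound 4 is therefore expected to give about 150000 nM, most likely reported only as a limit, in a range from 40000 nM to 600000 nM.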

Compound 4, half-maximal inhibitory concentration: > 100000 nM
Compound 4 was reported as a limit (the forecaster's own chance of this, stated with the estimate: 70%); the middle value does not contradict the limit.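

In this assay, among these compounds, compound 1 and compound 4 are both reported only as limits of the assay rather than as numbers, so no step between them can be read. The compounds shown leave open whether hydrogen in place of phenyl on a saturated chain carbon bound to an aromatic nitrogen changes inhibition at all, with most values resting at one limit: the limit of > 100000 nM in this assay, at which 3 of the 4 values shown sit.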